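A few compounds are considered here, and "the series" means these few. Any claim that something is new, unique, unknown or untested is made for them only; others in the source may bear on it.

Measured compounds in a functional assay on MCF7 cells (Homo sapiens) for antiproliferative activity, with a stated time of 48 h; a lower number here means a stronger inhibitor, a higher number a weaker inhibitor:
compound 1, `CCCCC(OC)c1cccc(NC(=O)NCCCCl)c1`, gives 50000 nM.
compound 2, `CCCCC(OC)c1cccc(NC(=O)NC(=O)CC)c1`, reaches only the limit of the assay, > 100000 nM.

Compound 2 thus stands at the weak end of the two numbers shown: its value is a limit, not a number, and it sits at the limit of > 100000 nM in this assay, at which 1 of the 2 values shown sits. Among the measured compounds shown here, the step of an at least 2.0-fold higher number from compound 1 to compound 2 (0.30 log units; that floor lies within the scatter) is the only measured step, and it is a floor within the scatter, so the true size of that step is not known.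

Compound 3, `CCCCC(OC)c1cccc(NC(=O)CCl)c1`, is not yet measured. It differs from compound 2 by chloromethyl in place of propanoylamino on a carbonyl carbon. The measured step bears on this change only loosely: the propanoyl that entered in the step from compound 1 to compound 2 now leaves again, and a chlorine-bearing group enters, as one was present in compound 1. From that single floor step, a move back towards the number of compound 1 is expected, with the size an at least 2.5-fold lower number from compound 2 to compound 3 (0.39 log units; beyond the scatter), but the step may also stay within the scatter. The estimate for compound 3 in this assay is 40000 nM, with a range from 8000 nM to 150000 nM.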

Compound 3, half-maximal inhibitory concentration: 12000 nM
Compound 3: the middle estimate sits 3.3-fold (0.52 log units) above what was measured; the measured number falls inside the stated range.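

In this assay, the carbonyl carbon proves to be a place where the number responds clearly to the group attached, with chloromethyl in place of propanoylamino giving an at least 8.3-fold lower number from compound 2 to compound 3 (0.92 log units; beyond the scatter). Compound 2 supplies only a limit, so this step is a floor and its true size stays unknown: the limit of > 100000 nM in this assay, at which 1 of the 3 values shown sits.

Chloromethyl in place of (3-chloropropyl)amino at the same carbonyl carbon gives the one step here with two real numbers at its ends, a 4.2-fold lower number from compound 1 to compound 3 (0.62 log units; beyond the scatter), so the gain in compound 3 does not rest on the limit alone, and a chlorine-bearing group on its own does not set the number, as compound 1 also carries chlorine.

The compounds shown do not separate the chlorine of compound 3 from the loss of the amino link or from the shortness of the group. Going by these compounds, a plain methyl, a bromomethyl or a longer chain such as 3-chloropropyl set directly on the same carbonyl carbon would tell these apart, and whether any such group goes beyond compound 3 stays open.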